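Working notes on a sulfonyl series: compound 1 to compound 4

This account rests on a few compounds, and the source may have more. Where it says the series, first, only, none or still open, it means among the compounds named here.

Of the compounds shown here, three have been measured in a functional assay on HeLa cells for agonist activity at 5-hydroxytryptamine receptor 6 (Homo sapiens), read by cAMP accumulation and immunoassay; a higher number here means that more compound is needed for the effect, a lower number that less compound is needed. Compound 1 `O=S(=O)(c1ccccc1Cl)c1cn(C2CCCNC2)c2ncccc12` gives 50 nM. Compound 3 `CCN1CCCC(n2cc(S(=O)(=O)c3ccc(Cl)s3)c3cccnc32)C1` gives 50 nM, which at the digits shown is level with compound 1; the two together stand at the lowest numbers of the three, and their difference lies within the scatter. Compound 2 `CN1CCCC(n2cc(S(=O)(=O)c3cccc(F)c3)c3cccnc32)C1` gives 306 nM, a number that lies furthest from compound 1, beyond the scatter. No two of the measured compounds differ in only one place, so no single step can be read off from them.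

Compound 4 `O=S(=O)(C1=C(Cl)NC2SC=CN12)c1cn(C2CCCNC2)c2ncccc12` is not yet measured. It differs from compound 1 in one place: a group of 9 heavy atoms (5 carbon, 2 nitrogen, 1 sulfur, 1 chlorine; 2 five-membered non-aromatic rings with 2 hetero atoms each) in place of a group of 7 heavy atoms (6 carbon, 1 chlorine; one six-membered aromatic ring of carbon only), on a sulfonyl sulfur. Within the data shown here, the group that enters has no counterpart among the measured compounds, which all carry a six-membered aromatic ring or another aromatic ring on the sulfonyl sulfur. Among the measured compounds shown here, there is therefore no measured step in this assay on which to rest a size. Given only this, a moderate rise in the number is expected, with wide uncertainty; the step of a 4.0-fold higher number from compound 1 to compound 4 (0.60 log units; beyond the scatter) is an estimate rather than a reading. For compound 4 the expected value in this assay is 200 nM, with a range from 40 nM to 1000 nM.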

Compound 4, half-maximal effective concentration: 66 nM
Compound 4: middle estimate off by 3.0-fold (0.48 log units), on the high side, within the range that was stated.
By their numbers in this assay, from the lowest: compounds 1, 3 and 4 (each within the scatter of the next); then compound 2.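

Among these compounds, the exchange of 2-chlorophenyl for the group of two five-membered non-aromatic rings, on a sulfonyl sulfur, gives the first single-place step: in this assay it is a 1.3-fold higher number from compound 1 to compound 4 (0.12 log units; within the scatter). At this position, then, a six-membered aromatic ring of carbon only is not needed to stay within the scatter of the starting number, even though the entering group is larger, has non-aromatic rings and carries a hydrogen-bond donor and hydrogen-bond acceptors that 2-chlorophenyl lacks. No measurement at hand explains why this exchange leaves the number within the scatter.

Among the compounds shown here, the single step cannot show which part of the entering group matters, nor whether a plain phenyl, a cyclohexyl or a group bearing a carboxylic acid on the sulfonyl sulfur would also remain within the scatter of compound 1. As far as these compounds go, compound 2 and compound 3 each differ from compound 1 in more than one place, so it also remains open whether this exchange would give a similar step on a compound with an alkyl group on the saturated ring's nitrogen, such as methyl or ethyl.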